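This account rests on a few compounds, and the source may have more. Where it says the series, first, only, none or still open, it means among the compounds named here.

Measured so far in an ADME assay on cells (Hepatocyte, Mus musculus) for metabolic stability, with a stated time of 30 min; a higher number here means that more of the compound is left, a lower number that less of the compound is left:

compound 1, `O=C(OC1CCC(CN2CCN(c3cc(=O)c4cc(C(F)(F)F)cc([N+](=O)[O-])c4s3)CC2)CC1)c1ccco1`: 0.6%
compound 2, `O=c1cc(N2CCN(CC3CCC(O)CC3)CC2)sc2c([N+](=O)[O-])cc(C(F)(F)F)cc12`: 51.2%
compound 3, `O=C(OC1CCC(CN2CCN(c3cc(=O)c4cc(C(F)(F)F)cc([N+](=O)[O-])c4s3)CC2)CC1)c1ccc(F)cc1`: 1.5%

Compound 3 stands second highest of these three numbers. Its nearest neighbour is compound 1, and the difference between them is small: a number 0.9 percentage points higher from compound 1 to compound 3 (within the scatter). Its furthest neighbour is compound 2, from which it is separated by a large gap: a number 49.7 percentage points lower from compound 2 to compound 3 (beyond the scatter). Both large steps, a number 50.6 percentage points higher from compound 1 to compound 2 (beyond the scatter) and the one just named, turn on whether the oxygen on the saturated carbon bears a hydrogen or a carbonyl group, not on which aromatic ring that carbonyl carries.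

Compound 4, `Cc1ccc(C(=O)OC2CCC(CN3CCN(c4cc(=O)c5cc(C(F)(F)F)cc([N+](=O)[O-])c5s4)CC3)CC2)cc1`, differs from compound 3 by one change: methyl in place of fluoro on an aromatic carbon. The step that bears on this change is the exchange of one aromatic ring for another on the same carbonyl carbon, from compound 1 to compound 3, which stayed within the scatter. The ester group that accompanies the low numbers of compound 1 and compound 3 is kept in compound 4. So this assay is expected to show no step beyond the scatter from compound 3 to compound 4, an expected step of a number 0.5 percentage points higher from compound 3 to compound 4 (within the scatter). Compound 4 is therefore estimated at 2%, within a range from 0% to 10%.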

Compound 4, percent of the compound remaining: 18%
For compound 4 the middle estimate is 16 percentage points below the measured one; measured number above the stated range.
By their numbers in this assay, from the lowest: compounds 1 and 3 (each within the scatter of the next); then compound 4; then compound 2.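

In this assay the substituent on the aromatic ring of the ester is not as silent as the earlier pair suggested: methyl in place of fluoro, para to a large group, gives a number 16.5 percentage points higher from compound 3 to compound 4 (beyond the scatter) and so moves the number beyond the scatter through the exchange of one heavy atom. The 4-methylphenyl group also separates from furan-2-yl, with a number 17.4 percentage points higher from compound 1 to compound 4 (beyond the scatter) as the step, although 4-fluorophenyl in place of furan-2-yl had stayed within the scatter. The ester still counts for more than this change, since the step of a number 33.2 percentage points lower from compound 2 to compound 4 (beyond the scatter) leaves the free hydroxyl of compound 2 highest of the four.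

Going by these compounds, whether a chloro or methoxy group in this place, or an amide in place of the ester, would move the number further remains open. No measurement shown bears on why methyl and fluoro differ here.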